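This account rests on a few compounds, and the source may have more. Where it says the series, first, only, none or still open, it means among the compounds named here.

Measured compounds:
Compound 1 `CC1=C(/C=C/C(=O)/C=C/c2ccc(Br)cc2)C(C)(C)CCC1` — in a functional assay on HeLa cells (Homo sapiens) for cytotoxicity, read by sulforhodamine B assay, with a stated time of 48 h (on this read-out higher numbers stand for weaker inhibition and lower numbers for stronger inhibition), compound 1 gives 88800 nM.
Compound 2 `COc1ccccc1/C=C/C(=O)/C=C/C1=C(C)CCCC1(C)C` — in this assay compound 2 gives 88200 nM.
Compound 3 `CC1=C(/C=C/C(=O)/C=C/c2ccccc2[N+](=O)[O-])C(C)(C)CCC1` — in this assay compound 3 gives 36100 nM.

Compound 3 holds the lowest of the three numbers, and its gaps to compound 2 and to compound 1 both lie beyond the scatter. Within the data shown here, the only single-change step measured so far is a 2.4-fold lower number from compound 2 to compound 3 (0.39 log units; beyond the scatter), a modest one. Compound 4 `CC1=C(/C=C/C(=O)/C=C/c2ccccc2F)C(C)(C)CCC1` differs from compound 3 by fluoro in place of nitro on an aromatic carbon, the new group standing on an aromatic carbon of a six-membered aromatic ring of carbon only, ortho to a large group. Among the measured compounds shown here, no measured step exchanges nitro for fluoro, so guidance is indirect: compound 2 and compound 1 carry other substituents on that ring and both sit at the higher numbers. The expectation is therefore that compound 4 gives back part of the lowering seen with nitro and moves toward those higher numbers, a modest step upward, a 1.9-fold higher number from compound 3 to compound 4 (0.29 log units; within the scatter). The estimated value for compound 4 is 70000 nM, within a range of 35000 nM to 140000 nM.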

Compound 4, half-maximal inhibitory concentration: 41900 nM
Compound 4: middle estimate off by 1.7-fold (0.22 log units), on the high side; low and high end bracket the measured number.
By their numbers in this assay, from the lowest: compounds 3 and 4 (each within the scatter of the next); then compounds 2 and 1 (each within the scatter of the next).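

In this assay, nitro and fluoro on an aromatic carbon ortho to a large group cannot be told apart (a 1.2-fold higher number from compound 3 to compound 4 (0.06 log units; within the scatter)), so the lower level does not depend on nitro, with its 3 heavy atoms and 2 hydrogen-bond acceptors; fluoro, with 1 heavy atom and no hydrogen-bond acceptors, sits at that level too. Fluoro in place of methoxy gives a modest step (a 2.1-fold lower number from compound 2 to compound 4 (0.32 log units; beyond the scatter)), and 2-fluorophenyl in place of 4-bromophenyl gives one of similar size (a 2.1-fold lower number from compound 1 to compound 4 (0.33 log units; beyond the scatter)), though the latter does not separate the change of halogen from the change of place. No available evidence bears on the origin of these steps. From the compounds shown here alone, whether an amine or a hydroxyl on this carbon would stay at the level of compound 3 and compound 4 remains open. So does whether fluoro elsewhere on the ring would hold that level.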